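Compound 3: phenyl replaces the substituted phenyl

This account rests on a few compounds, and the source may have more. Where it says the series, first, only, none or still open, it means among the compounds named here.

In a functional assay on DU-145 cells (Homo sapiens) for inhibition, read by sulforhodamine B assay, with a stated time of 48 h (a lower number here means a stronger inhibitor of growth, a higher number a weaker inhibitor of growth), compound 2 `COc1cc(-c2nn(-c3cccc(NC(=O)c4ccc(Cl)c(C(F)(F)F)c4)c3)cc2-c2ccncc2)ccc1Cl` gives the higher of the two numbers, 6390 nM, while compound 1 `COc1cc(-c2nn(-c3cccc(NC(=O)c4cccc(C(F)(F)F)c4)c3)cc2-c2ccncc2)ccc1Cl` gives 1760 nM. Compound 3 `COc1cc(-c2nn(-c3cccc(NC(=O)c4ccccc4)c3)cc2-c2ccncc2)ccc1Cl` has phenyl in place of 4-chloro-3-(trifluoromethyl)phenyl on a carbonyl carbon. Within the data shown here, the only measured step bearing on this is modest: a 3.6-fold higher number from compound 1 to compound 2 (0.56 log units; beyond the scatter), with chloro in place of hydrogen. Among the measured compounds shown here, compound 3 also lacks the chloro, but loss of trifluoromethyl has no measured step. A modest move to a lower number is therefore expected, with the estimated step of a 2.6-fold lower number from compound 2 to compound 3 (0.41 log units; beyond the scatter). The estimate for compound 3 is 2500 nM, with an expected range of 800 nM to 8000 nM.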

Compound 3, concentration for 50% growth inhibition: 780 nM
Compound 3: middle estimate off by 3.2-fold (0.51 log units), on the high side; the measured number lies below the stated range.
By their numbers in this assay, from the lowest: compound 3; then compound 1; then compound 2.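

On this phenyl, attached to the carbonyl carbon, the unsubstituted ring of compound 3 gives the lowest number of the three in this assay (an effect seen in both available steps: an 8.2-fold lower number from compound 2 to compound 3 (0.91 log units; beyond the scatter); a 2.3-fold lower number from compound 1 to compound 3 (0.35 log units; beyond the scatter)). Trifluoromethyl alone is now seen to raise the number, so among these compounds each added substituent goes with weaker growth inhibition, and none goes against this. No measurement available here explains the trend.

On these data alone, whether this holds for a small methoxy or an amine on the phenyl remains open. Also open, as far as these compounds go, is whether cyclohexyl could replace the phenyl.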